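Nitro exchange on the outer phenyl ring: expected cytotoxicity

This account rests on a few compounds, and the source may have more. Where it says the series, first, only, none or still open, it means among the compounds named here.

In an ADME assay on HepG2 cells (Homo sapiens) for cytotoxicity, read by MTT assay, with a stated time of 72 h (on this read-out higher numbers stand for lower toxicity in this test and lower numbers for higher toxicity in this test), compound 1 `CC1(c2ccc(-c3ccco3)cc2)CC(S(=O)(=O)c2ccc(F)cc2)=C(c2ccc(/C(N)=N\O)cc2)O1` gives 7010 nM. Compound 2 `CC1(c2ccc(-c3cccc([N+](=O)[O-])c3)cc2)CC(S(=O)(=O)c2ccc(F)cc2)=C(c2ccc(/C(N)=N\O)cc2)O1` reaches only a limit of the assay, > 50000 nM, so no number stands for it. Among the measured compounds shown here, the one measured step, an at least 7.1-fold higher number from compound 1 to compound 2 (0.85 log units; beyond the scatter), concerns a different exchange and is itself only bounded, since compound 2 sits at the limit of > 50000 nM in this assay, at which 1 of the 2 values shown sits. For the measured compounds named here, compound 3 `CC1(c2ccc(-c3cccc(/C(N)=N\O)c3)cc2)CC(S(=O)(=O)c2ccc(F)cc2)=C(c2ccc(/C(N)=N\O)cc2)O1` differs from compound 2 by a group of 4 heavy atoms (1 carbon, 2 nitrogen, 1 oxygen; no ring) in place of a group of 3 heavy atoms (1 nitrogen, 2 oxygen; no ring), on an aromatic carbon; no measured step touches this exchange. The step of a number no higher from compound 2 to compound 3 (the limit leaves the size open) is expected to stay within the scatter. Compound 3 is therefore estimated at 50000 nM, between 15000 nM and 100000 nM, most likely again a limit.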

Compound 3, half-maximal cytotoxic concentration: 19000 nM
The estimate for compound 3 lay 2.6-fold (0.42 log units) above the measured number; the measured number falls inside the stated range.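

In this assay, the group on this aromatic carbon, meta to a large group, matters even when nitro gives way to a group of similar size: an at least 2.6-fold lower number from compound 2 to compound 3 (0.42 log units; beyond the scatter). Against furan-2-yl, a measured difference remains, a 2.7-fold higher number from compound 1 to compound 3 (0.43 log units; beyond the scatter), so this exchange now has an exact size. The size of the nitro exchange stays bounded only, because compound 2 stands at a limit: the limit of > 50000 nM in this assay, at which 1 of the 3 values shown sits.

From the compounds shown here alone, whether an amine or a carboxylic acid on this carbon would give a lower or a higher number remains open. So does the effect of a methyl ether in the same place.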